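The compounds below may be only part of what the source reports. "The series", "measured", "known", "first", "only" and "open" are said of these compounds alone.

Working notes on the series. In a functional assay on BXPC-3 cells (Homo sapiens) for cytotoxicity, read by fluorescence, with a stated time of 48 h (on this read-out higher numbers stand for an effect only at larger amounts of compound and lower numbers for an effect already at smaller amounts), compound 1 (`CC(C)=CCC/C(C)=C/CC/C(C)=C/CSC[C@H](NC(=O)CCCCCN1CCN(C)CC1)C(=O)NC1CCCCCC1`) gives 6200 nM as its reading. The nearest number belongs to compound 2 (`CC(C)=CCC/C(C)=C/CC/C(C)=C/CSC[C@H](NC(=O)CCCCCN1CCCC1)C(=O)NC1CCCC1`) at 6800 nM and lies within the scatter of compound 1. The furthest belongs to compound 3 (`CC(C)=CCC/C(C)=C/CC/C(C)=C/CSC[C@H](NC(=O)CCCCCN1CCN(C)CC1)C(=O)N1CCCC1`) at 3200 nM and also lies within the scatter of compound 1.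

The change under study leads to compound 4 (`CC(C)=CCC/C(C)=C/CC/C(C)=C/CSC[C@H](NC(=O)CCCCCN1CCN(C)CC1)C(=O)NC1CCCC1`), with cyclopentyl in place of cycloheptyl on an amide-type nitrogen, counted in full as cyclopentyl in place of cycloheptyl on an amide-type nitrogen for this pair.

The closest measured step is a 1.9-fold lower number from compound 1 to compound 3 (0.29 log units; within the scatter) with pyrrolidin-1-yl in place of cycloheptylamino on a carbonyl carbon. That step replaces the same cycloheptylamino group and did not leave the scatter. Within the data shown here, compound 2 also carries cyclopentyl on an amide-type nitrogen, but it differs from compound 1 in a second place as well, so its value offers only a rough guide and no clean step.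

No step beyond the scatter is therefore expected in this assay and no direction can be firmly expected. The estimated step is a 1.1-fold lower number from compound 1 to compound 4 (0.05 log units; within the scatter) and is expected to stay small. For compound 4 the estimate is 5500 nM with an expected range from 3000 nM to 10000 nM on this read-out.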

Compound 4, half-maximal effective concentration: > 20000 nM
Compound 4: a limit, no number; the forecaster's own chance of this, stated with the estimate: 2%; middle value at least 3.6-fold (0.56 log units) from the limit.
By their numbers in this assay, from the lowest: compounds 3, 1 and 2 (each within the scatter of the next, the first and the last beyond it). At a limit, above all of these: compound 4.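

In this assay compound 4 gives > 20000 nM, which is a limit of the assay and not a number, so every step to it fixes only a lower bound on size: the limit of > 20000 nM in this assay, at which 1 of the 4 values shown sits.

Among these compounds, the amide-type nitrogen now shows a sensitivity that the earlier compounds, all within the scatter of compound 1, did not reveal: cyclopentyl in place of cycloheptyl gives an at least 3.2-fold higher number from compound 1 to compound 4 (0.50 log units; beyond the scatter), and cyclopentylamino in place of pyrrolidin-1-yl on a carbonyl carbon gives an at least 6.2-fold higher number from compound 3 to compound 4 (0.79 log units; beyond the scatter). Cyclopentylamino does not settle the reading on its own, since 4-methylpiperazin-1-yl in place of pyrrolidin-1-yl on a saturated chain carbon, five bonds along the chain from a carbonyl carbon, gives an at least 2.9-fold higher number from compound 2 to compound 4 (0.46 log units; beyond the scatter), so the effect of this change depends on the group at the end of the chain.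

The compounds shown leave open how far the reading of compound 4 lies past its limit, and whether cyclohexyl on the amide-type nitrogen would read with cycloheptyl or with cyclopentyl. They also leave open whether a piperidin-1-yl or morpholin-4-yl group at the chain end would behave with cyclopentylamino as pyrrolidin-1-yl does or as 4-methylpiperazin-1-yl does.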